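The source may hold more compounds than are shown below. What is called first, only, known or untested is meant among the compounds shown, and "the series" means these compounds.

Measured so far:
compound 1 `COc1ccc(OC)c(/C=N/NC(=O)c2cc(OC)c(OC)c(OC)c2)c1` — 10.1%
compound 2 `COc1cc(C2=NN(C(C)=O)C(c3ccccc3C(F)(F)F)O2)cc(OC)c1OC` — 34.8%

In a functional assay on BGC-823 cells (Homo sapiens) for antiproliferative activity, read by MTT assay, tested at 5 uM (on this read-out higher numbers stand for a stronger effect at the one concentration tested and lower numbers for a weaker effect), compound 2 gives 34.8% and stands highest of the two numbers shown; compound 1, the nearest, gives 10.1%, a gap that lies beyond the usual scatter. For the measured compounds named here, no step between measured compounds differing in one place has been worked out, so the two values are all that can be said of that pair.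

Compound 3 `COc1ccc(OC)c(C2OC(c3cc(OC)c(OC)c(OC)c3)=NN2C(C)=O)c1` has not been measured in this assay. It differs from compound 2 in one place:
2,5-dimethoxyphenyl in place of 2-(trifluoromethyl)phenyl on a saturated ring carbon

The 2,5-dimethoxyphenyl group that enters is the same aryl that compound 1 carries on a different core, where compound 1 gives 10.1%. Going by the values given here, that is the only guide to the direction of the step. The expected step from compound 2 to compound 3 is a number 9.8 percentage points lower from compound 2 to compound 3 (within the scatter), a modest fall that may or may not pass beyond the scatter. Compound 3 is accordingly estimated at 25% in this assay, within a range from 8% to 45%.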

Compound 3, a percentage reported as inhibition, at one concentration (the size of the read-out at that concentration, not a potency): 18.2%
The estimate for compound 3 lay 6.8 percentage points above the measured number, within the range that was stated.
By their numbers in this assay, from the lowest: compounds 1 and 3 (each within the scatter of the next); then compound 2.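

In this assay, for the compounds shown here, putting 2,5-dimethoxyphenyl in place of 2-(trifluoromethyl)phenyl on the saturated ring carbon gives a number 16.6 percentage points lower from compound 2 to compound 3 (beyond the scatter), the one step that can be read at a single changed place. With the rest of the core held constant, the read-out at this concentration therefore responds to the aryl group on this carbon, even though both groups hold one six-membered aromatic ring of carbon only and the same number of heavy atoms, with 2 hydrogen-bond acceptors in the entering group and 0 in the one that leaves. No measurement to hand connects the step to any particular feature of either group.

A single exchange cannot separate the loss of the trifluoromethyl group from the gain of the two methoxy groups, and a plain phenyl or a 2-methoxyphenyl on this carbon would bear on that question. Also open, on these data alone, is how far the read-out would move if a longer acyl chain or an amine-bearing chain stood in place of the acetyl group, which is the same in compound 2 and compound 3.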